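Working notes on cytotoxicity, compound 1 to compound 4

A few compounds are considered here, and "the series" means these few. Any claim that something is new, unique, unknown or untested is made for them only; others in the source may bear on it.

The series is followed in an ADME assay on Vero cells (Chlorocebus sabaeus) for cytotoxicity, read by MTT assay, with a stated time of 72 h; on this read-out lower numbers stand for higher toxicity in this test and higher numbers for lower toxicity in this test. Compound 1 `O=C1Oc2ccccc2N/C1=C\C(=O)c1cccs1` returns only a limit in this assay, > 1840000 nM, which is a limit of the assay and not a number. Compound 2 `COC(=O)/C=C1/Oc2ccccc2NC1=O` has no result in this assay, "not determined" (no result reported). Compound 3 `O=C(NNC(=O)c1ccncc1)C(=O)Nc1ccc(Cl)cc1O` gives 1170000 nM in this assay. Compound 1 therefore stands at the limit, as the entry the limit of > 1840000 nM in this assay, at which 1 of the 3 values shown sits, records, while compound 3 is the only entry carrying a single number. Within the data shown here, no step between measured compounds is available in this assay.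

Compound 4 `O=C1Oc2ccccc2N/C1=C\C(=O)c1cccc(Cl)c1` differs from compound 1 by 3-chlorophenyl in place of thiophen-2-yl on a carbonyl carbon, in words 3-chlorophenyl in place of thiophen-2-yl on a carbonyl carbon. The shared core is otherwise untouched. Among the measured compounds shown here, compound 1 sits at the limit, and no measured step exists in this assay. The step expected here is an at least 1.2-fold lower number from compound 1 to compound 4 (0.08 log units; that floor lies within the scatter), within the usual scatter and with no direction beyond it. Compound 4 is estimated at 1500000 nM in this assay, with a range from 400000 nM to 4000000 nM, and a fair chance that again only a limit is reported.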

Compound 4, half-maximal cytotoxic concentration: 1610000 nM
For compound 4 the middle estimate is 1.1-fold (0.03 log units) below the measured one; the range from low to high includes it.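

Among these compounds, compound 4 gives the first single number on the core of compound 1, showing that 3-chlorophenyl in place of thiophen-2-yl on this carbonyl carbon yields a reading that is not a limit in this assay. The change reads as an at least 1.1-fold lower number from compound 1 to compound 4 (0.05 log units; that floor lies within the scatter), so only a floor on the step is known and no direction beyond the usual scatter can be claimed. Compound 1 itself remains a limit of the assay and not a number: the limit of > 1840000 nM in this assay, at which 1 of the 4 values shown sits.

As far as these compounds go, whether the ring exchange or the chlorine matters at this place stays open, and a plain phenyl would separate the two. Also open, from the compounds shown here alone, is whether an amine or a carboxylic acid on this carbonyl carbon would move the number in this assay beyond the scatter.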